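Methyl on the Aryl Ring: From Compound 1 to Compound 4

A few compounds are considered here, and "the series" means these few. Any claim that something is new, unique, unknown or untested is made for them only; others in the source may bear on it.

Of the compounds shown here, three sharing one core have been tested in a functional assay on the whole organism (strain Swiss) with Mus musculus as the target, in the maximal electroshock model, with a stated time of 0.5 h, at a dose of 100 mg/kg by the intraperitoneal route; on this read-out higher numbers stand for a stronger effect at the one dose given and lower numbers for a weaker effect. Compound 1 `CC(C(=O)N1CCN(c2ccccc2)CC1)N1C(=O)CCC1=O` gives 0%. Compound 2 `CCC(C(=O)N1CCN(c2cccc(F)c2)CC1)N1C(=O)CCC1=O` gives 0%, and compound 3 `CCC(C(=O)N1CCN(c2cccc(Cl)c2)CC1)N1C(=O)CCC1=O` gives 50%. Compound 1 thus stands level with compound 2 at the digits shown, and together they are the lowest of the three numbers; compound 3 sits above them, beyond the scatter. Going by the values given here, the only one-place step among the measured compounds is a number 50 percentage points higher from compound 2 to compound 3 (beyond the scatter), which shows that swapping one group on the aromatic ring can move the read-out strongly.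

Compound 4 `Cc1cccc(N2CCN(C(=O)C(C)N3C(=O)CCC3=O)CC2)c1` differs from compound 1 in one place: methyl in place of hydrogen on an aromatic carbon. Among the compounds with values here, no measured step involves a methyl group, so the change from compound 1 to compound 4 has no direct precedent. The step from compound 2 to compound 3 bears on it only loosely, as it concerns the same aromatic ring in compounds that also carry an ethyl rather than a methyl chain on the core. Some rise in this assay is therefore plausible but uncertain, and the expected step is a number 15 percentage points higher from compound 1 to compound 4 (beyond the scatter). For compound 4 the estimated value is 15%, with a range from 0% to 50%.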

Compound 4, a percentage reported as activity, at one dose (the size of the read-out at that dose, not a potency): 0%
The estimate for compound 4 lay 15 percentage points above the measured number, and the stated range covers the measured number.
By their numbers in this assay, from the lowest: compounds 1, 2 and 4 (each within the scatter of the next); then compound 3.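

In this assay, methyl in place of hydrogen on an aromatic carbon, meta to a large group, gives no change at the digits printed from compound 1 to compound 4 (within the scatter), so the change from phenyl to 3-methylphenyl does not lift the read-out on this core at the one dose given. The large step of a number 50 percentage points higher from compound 2 to compound 3 (beyond the scatter) therefore does not extend to this methyl change, which also sits on a core with a methyl rather than an ethyl chain; a single substituent swap can matter greatly in one pair and show nothing in another. No measurement shown here accounts for this flat result.

Since compound 1 and compound 4 both sit at the bottom of the read-out, this pair cannot tell whether methyl has a small effect that this one dose fails to reveal. Still open, going by these compounds, is whether chloro at this same place would raise the read-out on the core of compound 1, and whether methyl, or another group such as methoxy or trifluoromethyl, would do so on the core with the ethyl chain.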